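Cytotoxicity across three amide variants of a shared core

This account rests on a few compounds, and the source may have more. Where it says the series, first, only, none or still open, it means among the compounds named here.

The series rests on a shared core, carried by compound 1 `CC(Sc1nnc(-c2ccncc2)s1)C(=O)Nc1ccccc1Cl`, compound 2 `CC(Sc1nnc(-c2ccncc2)s1)C(=O)NCc1ccc(Cl)cc1` and the still unmeasured compound 3 `CC(Sc1nnc(-c2ccncc2)s1)C(=O)Nc1c(Cl)cccc1Cl`. In an ADME assay on HepG2 cells (Homo sapiens) for cytotoxicity, with a stated time of 3 days (on this read-out lower numbers stand for higher toxicity in this test and higher numbers for lower toxicity in this test), compound 1 gives > 50000 nM, which is a limit of the assay and not a number. For compound 2 this assay reports "not determined" (no result reported), so no value places it on the scale. The one anchor is therefore (the limit of > 50000 nM in this assay, at which 1 of the 2 values shown sits). Within the data shown here, the change under study is 2,6-dichlorophenyl in place of 4-chlorobenzyl on an amide-type nitrogen; no step between two measured compounds is available to size its effect, and nothing in the data points to a direction beyond the scatter. Given that compound 1 reached only the limit, compound 3 is expected to sit near that limit, with an estimated half-maximal cytotoxic concentration of 45000 nM, between 12000 nM and 50000 nM. What this assay actually reports for compound 3 follows.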

Compound 3, half-maximal cytotoxic concentration: > 50000 nM
Compound 3 gave a limit, no number; the forecaster's own chance of this, stated with the estimate: 65%; middle value at least 1.1-fold (0.04 log units) away from the limit.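

In this assay, among these compounds, compound 1 and compound 3 both stand at a limit, so no step between them can be read, and compound 2 offers no number for comparison. The compounds shown leave open whether changing the group on the amide nitrogen alters cytotoxicity at all.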